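Three Amines at the Limit, a Fourth Expected There

The compounds below may be only part of what the source reports. "The series", "measured", "known", "first", "only" and "open" are said of these compounds alone.

Measured so far in an assay on isolated protein for binding affinity to 5-hydroxytryptamine receptor 3A (Homo sapiens); on this read-out lower numbers stand for stronger inhibition and higher numbers for weaker inhibition:
- compound 1 `CCN(CC)Cc1ccc(Cl)c(-c2ccccc2OC)c1`: > 10000 nM
- compound 2 `CCCCNCc1ccc(Cl)c(-c2ccccc2OC)c1`: > 10000 nM
- compound 3 `CNCc1ccc(Cl)c(-c2ccccc2OC)c1`: > 10000 nM

Compound 1 gives in this assay only a limit of the assay, not a number. Compound 2 likewise gives only a limit in this assay. Compound 3 also gives only a limit in this assay. Because (the limit of > 10000 nM in this assay, at which 3 of the 3 values shown sit), none of the three can be placed on a scale, and the measured steps stay unreadable: a step that the two limits leave unreadable from compound 1 to compound 2, a step that the two limits leave unreadable from compound 1 to compound 3 and a step that the two limits leave unreadable from compound 2 to compound 3.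

Compound 4 `CCCNCc1ccc(Cl)c(-c2ccccc2OC)c1` is not yet measured. It differs from compound 1 in one place: propylamino in place of diethylamino on a saturated chain carbon bound to an aromatic carbon. The propylamino group stands in chain length between the methylamino of compound 3 and the butylamino of compound 2, and both of those, like compound 1, sit at the limit. The step from compound 1 to compound 4 is therefore expected to be a step that the limit leaves unreadable from compound 1 to compound 4, that is, not readable. Compound 4 is expected to give about 20000 nM, within 8000 nM to 60000 nM, most likely as a limit again.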

Compound 4, inhibition constant: > 10000 nM
Compound 4 gave a limit, no number; the forecaster's own chance of this, stated with the estimate: 85%; the middle value does not contradict the limit.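

Compound 4 gives only a limit in this assay, as do compound 1, compound 2 and compound 3, so no step among these four can be read: the limit of > 10000 nM in this assay, at which 4 of the 4 values shown sit.

The compounds shown leave open whether any amine on the shared core gives a measurable value in this assay, and how these amines would rank.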